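The source may report more compounds than this note shows. Statements on the series, on what has been measured and on what is new or still open speak of the compounds shown alone.

Measured so far in an ADME assay on THP-1 cells (Homo sapiens) for cytotoxicity; on this read-out lower numbers stand for higher toxicity in this test and higher numbers for lower toxicity in this test:
Compound 1 `COc1ccc(NC(=O)c2c(NC(=O)C(F)(F)F)sc3c2CCC3)cc1`: > 50000 nM
Compound 2 `COc1ccccc1NC(=O)c1c(NC(=O)C(F)(F)F)sc2c1CCCCC2`: > 50000 nM
Compound 3 `CC(C)(C)OC(=O)c1c(N)sc2c1CCCCC2`: > 50000 nM

Every entry is a limit of the assay and not a number, namely (the limit of > 50000 nM in this assay, at which 3 of the 3 values shown sit). Compound 3 stands at > 50000 nM, which is a limit. No order among the three compounds can be drawn from these entries.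

Next in the series is compound 4 `CC(=O)Nc1sc2c(c1C(=O)OC(C)(C)C)CCCCC2`. Its difference from compound 3 is acetyl in place of hydrogen on a nitrogen on an aromatic ring. In short, this is amino to acetamido, with acetyl in place of hydrogen on a nitrogen on an aromatic ring.

Among the measured compounds shown here, no two measured compounds differ in one place, so the series offers no measured step for this change. The nearest guide is that compound 2 also carries an acylated nitrogen on an aromatic ring, and its > 50000 nM is a limit. Compound 1 shares that feature, and its > 50000 nM is a limit too.

No change beyond the usual scatter is expected in this assay, and neither direction is favoured. The expected move is a number no higher from compound 3 to compound 4 (the limit leaves the size open). Compound 4 is estimated at 50000 nM, with an expected range from 20000 nM to 100000 nM, and a report of only a limit is the likeliest outcome.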

Compound 4, half-maximal cytotoxic concentration: > 50000 nM
Compound 4 gave a limit, no number (the forecaster's own chance of this, stated with the estimate: 85%); the middle value lies on the limit itself.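

In this assay compound 4 gives > 50000 nM, a limit and not a number. Compound 3 gives > 50000 nM, also a limit, so no step can be read for acetyl in place of hydrogen on the nitrogen. The compounds shown leave open which structural change, if any, would give a numerical value, with every entry at one limit: the limit of > 50000 nM in this assay, at which 4 of the 4 values shown sit.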